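Thiophen-2-yl in place of allyl on compound 1

This account rests on a few compounds, and the source may have more. Where it says the series, first, only, none or still open, it means among the compounds named here.

- Compound 1 `C=CCOc1ccc2c(c1)C(=O)C=CC2=O` in a functional assay on HeLa cells (Homo sapiens) for cytotoxicity; a lower number here means a stronger inhibitor, a higher number a weaker inhibitor: 27200 nM
- Compound 2 `CC(=O)OC1=CC(=O)c2ccccc2C1=O` in this assay: 62100 nM

For the measured compounds named here, only these two compounds have numbers so far. Compound 1 holds the lower of them, at 27200 nM, while compound 2 reads 62100 nM, a gap that lies beyond the usual scatter. Compound 1 is therefore the stronger inhibitor of the pair in this assay, though neither number is small.

Compound 3 `O=C1C=CC(=O)c2cc(Oc3cccs3)ccc21` has not yet been measured. It keeps the core of compound 1 and carries thiophen-2-yl in place of allyl on an oxygen on an aromatic ring. Going by the values given here, no two measured compounds differ in one place only, so the data show no direct precedent for a change of this kind, and any forecast stays loose. Only a small move toward a lower number is expected, one that stays within the scatter. The estimated step is a 1.4-fold lower number from compound 1 to compound 3 (0.13 log units; within the scatter). In this assay the expected value of compound 3 is 20000 nM, with an estimated range of 6000 nM to 60000 nM.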

Compound 3, half-maximal inhibitory concentration: 8860 nM
The estimate for compound 3 lay 2.3-fold (0.35 log units) above the measured number, within the range that was stated.
By their numbers in this assay, from the lowest: compound 3; then compound 1; then compound 2.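

In this assay, for the compounds shown here, the step from allyl to thiophen-2-yl gives a 3.1-fold lower number from compound 1 to compound 3 (0.49 log units; beyond the scatter) and is the first reading of a single change at this position, an oxygen on an aromatic ring; compound 2 differs from compound 1 in more than one place, so the earlier pair could not show this. The position accepts a five-membered aromatic ring with one sulfur atom in place of an open chain with a double bond, and the number falls rather than rises, although it still lies in the same broad range as the numbers before it. Nothing at hand explains why the number falls with this change.

The compounds shown do not tell whether the sulfur atom, the aromatic ring or simply the larger group goes with the lower number, and phenyl or furan-2-yl on the same oxygen would begin to separate these. They also leave open how a longer alkyl chain on that oxygen would read, or an amine or a carboxylic acid on the thiophene ring, since a single step sets no trend.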